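The source may hold more compounds than are shown below. What is called first, only, known or untested is meant among the compounds shown, and "the series" means these compounds.

Series values in a functional assay on MDA-MB-231 cells (Homo sapiens) for inhibition, read by WST assay, with a stated time of 48 h; a lower number here means a stronger inhibitor of growth, a higher number a weaker inhibitor of growth:

- compound 1 `CC/C=C\C/C=C\C/C=C\C/C=C\C/C=C\C/C=C\CCC(=O)Oc1ccc(C(C)C)cc1C(C)C`: 12600 nM
- compound 2 `CC/C=C\C/C=C\C/C=C\C/C=C\C/C=C\C/C=C\CCC(=O)Oc1ccccc1C(C)C`: 12100 nM

With only these two numbers available, compound 2 at 12100 nM sits level with compound 1 within the scatter, so neither stands out.

The next step leads to compound 3 `CC/C=C\C/C=C\C/C=C\C/C=C\C/C=C\C/C=C\CCC(=O)Oc1c(C(C)C)cccc1C(C)C`, where 2-isopropylphenyl becomes 2,6-diisopropylphenyl: isopropyl in place of hydrogen on an aromatic carbon.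

For the measured compounds named here, only one measured step bears on this change: a 1.0-fold lower number from compound 1 to compound 2 (0.02 log units; within the scatter). That step also exchanges hydrogen and isopropyl, but on a different aromatic carbon and in the opposite direction, so it is only indirect evidence. It lies within the scatter and gives no sign of a trend with the number of isopropyl groups. Going by the values given here, the data hold no compound with the new substitution pattern, so the uncertainty remains wider than the single step suggests.

In this assay, the expected change is small and no shift beyond the scatter is expected: a 1.2-fold higher number from compound 2 to compound 3 (0.06 log units; within the scatter).

The estimated value for compound 3 is 14000 nM, with an expected range of 7000 nM to 30000 nM.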

Compound 3, concentration for total growth inhibition: 4200 nM
Compound 3: the middle estimate sits 3.3-fold (0.52 log units) above what was measured; measured number below the stated range.
By their numbers in this assay, from the lowest: compound 3; then compounds 2 and 1 (each within the scatter of the next).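

In this assay, for the compounds shown here, the change from 2-isopropylphenyl to 2,6-diisopropylphenyl gives the first step beyond the scatter (a 2.9-fold lower number from compound 2 to compound 3 (0.46 log units; beyond the scatter)), whereas the earlier exchange of isopropyl and hydrogen on a different aromatic carbon stayed within it (a 1.0-fold lower number from compound 1 to compound 2 (0.02 log units; within the scatter)). The step from the 2,4-diisopropylphenyl compound to the 2,6-diisopropylphenyl compound is also beyond the scatter (a 3.0-fold lower number from compound 1 to compound 3 (0.48 log units; beyond the scatter)), so among these three compounds the number of isopropyl groups alone does not order the values: compound 1 carries two isopropyl groups yet stands level with compound 2, which carries one, within the scatter. Placement of the second isopropyl on the aromatic ring therefore matters in this small set, but no measurement at hand accounts for the difference.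

The compounds shown leave open whether this pattern depends on isopropyl itself, as they include no 2,6-dimethylphenyl, 2,6-di-tert-butylphenyl or 2,6-dimethoxyphenyl partner. They also leave open whether the step would hold with an amide in place of the ester link, or with a shorter fatty acid chain on the same 2,6-diisopropylphenyl group.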